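This account rests on a few compounds, and the source may have more. Where it says the series, first, only, none or still open, it means among the compounds named here.

Of the compounds shown here, two sharing one core have so far been measured in a functional assay on HT-29 cells (Homo sapiens) for antiproliferative activity, read by sulforhodamine B assay, with a stated time of 48 h; a higher number here means a weaker inhibitor, a lower number a stronger inhibitor. Compound 1 `CCc1ccccc1OS(=O)(=O)c1ccc(N2CCN(C)C2=O)cc1` gives 4600 nM, and compound 2 `CN1CCN(c2ccc(S(=O)(=O)Oc3cccc(Cl)c3)cc2)C1=O` gives 2100 nM, the lower of the two numbers. For the measured compounds named here, the one measured step, which puts 3-chlorophenyl in place of 2-ethylphenyl on an oxygen, is modest: a 2.2-fold lower number from compound 1 to compound 2 (0.34 log units; beyond the scatter).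

The next compound is compound 3 `Cc1ccc(OS(=O)(=O)c2ccc(N3CCN(C)C3=O)cc2)cc1`. Its difference from compound 2 is 4-methylphenyl in place of 3-chlorophenyl on an oxygen whose other neighbour is the sulfonyl sulfur. Going by the values given here, no measured compound carries the 4-methylphenyl group, so the evidence is indirect. Among the compounds with values here, the only guide is the size of the change seen when the group on this oxygen was exchanged between the two measured compounds, a 2.2-fold lower number from compound 1 to compound 2 (0.34 log units; beyond the scatter). A step no larger than that one is therefore expected in this assay, leaning towards a higher number, as compound 2 holds the lower value of the pair. The expected change is a 1.4-fold higher number from compound 2 to compound 3 (0.15 log units; within the scatter). Compound 3 is estimated at 3000 nM, with an expected range of 1200 nM to 8000 nM.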

Compound 3, half-maximal inhibitory concentration: > 100000 nM
Compound 3 was reported as a limit; the forecaster's own chance of this, stated with the estimate: 5%; middle value at least 33-fold (1.52 log units) away from the limit.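

Exchanging the group on the oxygen whose other neighbour is the sulfonyl sulfur proves far less forgiving than the first pair suggested, which had shown only a 2.2-fold lower number from compound 1 to compound 2 (0.34 log units; beyond the scatter). Against that modest step, 4-methylphenyl in place of 3-chlorophenyl gives an at least 47-fold higher number from compound 2 to compound 3 (1.67 log units; beyond the scatter), and 4-methylphenyl in place of 2-ethylphenyl gives an at least 21-fold higher number from compound 1 to compound 3 (1.33 log units; beyond the scatter), even though 3-chlorophenyl and 4-methylphenyl have the same count of heavy atoms and the same six-membered aromatic ring of carbon only. In this assay compound 3 is recorded only as a limit, > 100000 nM, so both large steps are lower bounds and their full size cannot be read: the limit of > 100000 nM in this assay, at which 1 of the 3 values shown sits.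

The compounds shown leave open whether the loss follows the methyl group itself or the place it occupies on the ring, as 4-methylphenyl differs from 3-chlorophenyl in both respects. They also leave open how a plain phenyl group or a methoxyphenyl group on the same oxygen would compare in this series.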